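The source may report more compounds than this note shows. Statements on the series, on what has been measured and on what is new or still open speak of the compounds shown alone.

Measured so far in an ADME assay on microsomes from liver (Homo sapiens) for metabolic stability, with a stated time of 30 min, tested at 1 uM; on this read-out higher numbers stand for a longer-lived compound and lower numbers for a shorter-lived compound:
- Compound 1, `COc1ccc2[nH]c(C(=O)N3CC(=O)N(Cc4ccccc4)[C@@H](COc4ccccc4)C3)cc2c1`: 0.65 h
- Compound 2, `O=C(c1cc2cc(C3CC3)ccc2[nH]1)N1CC(=O)N(Cc2ccccc2)[C@@H](CN2CCC(F)CC2)C1`: 0.383 h
- Compound 3, `COc1ccc2[nH]c(C(=O)N3CC(=O)N(Cc4ccccc4)[C@@H](N4CCc5ccccc54)C3)cc2c1`: 0.25 h

Compound 3 gives the lowest of the three numbers in this assay. Its nearest neighbour is compound 2, whose value lies within the usual scatter of compound 3, so no order between those two can be read. Going by the values given here, compound 1 stands furthest away: the single change from compound 1 to compound 3 gave a 2.6-fold lower number from compound 1 to compound 3 (0.41 log units; beyond the scatter).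

Compound 4, `COc1ccc2[nH]c(C(=O)N3CC(=O)N(Cc4ccccc4)[C@@H](CN4CCc5ccccc5C4)C3)cc2c1`, has not yet been measured. It differs from compound 3 in one place: (1,2,3,4-tetrahydroisoquinolin-2-yl)methyl in place of 2,3-dihydro-1H-indol-1-yl on a saturated ring carbon. Among the compounds with values here, no measured step covers this exact exchange. Within the data shown here, the only step that touches the same ring carbon is the one from compound 1 to compound 3, which was modest in size, and compound 2 carries a group at that position that, like the incoming group, is joined through a single carbon to a ring nitrogen, and compound 2 gives a number within the scatter of compound 3. On that basis only a small change is expected in this assay, if any, with the direction open. Compound 4 is therefore estimated at 0.35 h, with a range from 0.13 h to 0.9 h, which corresponds to an expected step of a 1.4-fold higher number from compound 3 to compound 4 (0.15 log units; within the scatter).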

Compound 4, half-life: 0.617 h
For compound 4 the middle estimate is 1.8-fold (0.25 log units) below the measured one, and the stated range covers the measured number.
By their numbers in this assay, from the lowest: compounds 3, 2, 4 and 1 (each within the scatter of the next, the first and the last beyond it).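

In this assay, the saturated ring carbon next to the ring atom that bears a benzyl group now shows a step upward as well as the earlier step downward: (1,2,3,4-tetrahydroisoquinolin-2-yl)methyl in place of 2,3-dihydro-1H-indol-1-yl gives a 2.5-fold higher number from compound 3 to compound 4 (0.39 log units; beyond the scatter). Putting 1,2,3,4-tetrahydroisoquinolin-2-yl in place of phenoxy on the saturated chain carbon bound to that ring carbon gives a 1.1-fold lower number from compound 1 to compound 4 (0.02 log units; within the scatter), so this assay does not separate those two groups. Read together, these steps set compound 3, whose group sits directly on the ring carbon, apart from compound 1 and compound 4, whose groups are held on the chain carbon.

No measurement shown here explains these differences. On these data alone, the step to compound 4 changes both the attachment through the chain carbon and the five-membered non-aromatic ring to a six-membered one, so the share of each stays open, as does the outcome for a longer chain between the ring carbon and the tetrahydroisoquinoline, or for a simple open-chain amine such as dimethylamino on the chain carbon.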